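Methoxy Added to the Benzyl Group of Compound 3

This account rests on a few compounds, and the source may have more. Where it says the series, first, only, none or still open, it means among the compounds named here.

Measured so far in a functional assay on HT-29 cells (Homo sapiens) for cytotoxicity, read by MTT assay, with a stated time of 24 h, tested at 1.6 ug/mL; a higher number here means a stronger effect of the compound at the concentration tested, a lower number a weaker effect:
compound 1, `CCN1CCN(CC(=O)Nc2ccc(-c3nc(-c4ccccc4)c(-c4ccccc4)n3C)cc2)CC1`: compound 1 gives 13.9%
compound 2, `Cn1c(-c2ccc(NC(=O)CN3CCN(c4ccccc4)CC3)cc2)nc(-c2ccccc2)c1-c1ccccc1`: compound 2 gives 26%
compound 3, `Cn1c(-c2ccc(NC(=O)CN3CCN(Cc4ccccc4)CC3)cc2)nc(-c2ccccc2)c1-c1ccccc1`: compound 3 gives 26%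

Compound 3 stands level with compound 2, within the scatter, and the two share the highest numbers of the three; compound 1 sits furthest away, with a number 12.1 percentage points higher from compound 1 to compound 3 (beyond the scatter). Compound 4, `COc1ccc(CN2CCN(CC(=O)Nc3ccc(-c4nc(-c5ccccc5)c(-c5ccccc5)n4C)cc3)CC2)cc1`, differs from compound 3 by methoxy in place of hydrogen on an aromatic carbon. The measured steps all concern the group on the amine nitrogen in a ring: a number 12.1 percentage points higher from compound 1 to compound 2 (beyond the scatter), a number 12.1 percentage points higher from compound 1 to compound 3 (beyond the scatter), and no change at the digits printed from compound 2 to compound 3 (within the scatter). For the measured compounds named here, no measured step adds a methoxy to an aromatic carbon, so nothing here speaks for a shift; a step of no change at the digits printed from compound 3 to compound 4 (within the scatter) is expected, within the scatter. Compound 4 is therefore estimated at 26%, ranging from 12% to 42%.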

Compound 4, a percentage reported as activity, at one concentration (the size of the read-out at that concentration, not a potency): 10.1%
Compound 4: middle estimate off by 15.9 percentage points, on the high side; the whole stated range lies above it.
By their numbers in this assay, from the lowest: compounds 4 and 1 (each within the scatter of the next); then compounds 2 and 3 (each within the scatter of the next).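

In this assay, for the compounds shown here, the aromatic ring of the benzyl group turns out to respond to substitution, which the earlier compounds could not show, as they varied only the group on the amine nitrogen: methoxy on that ring gives a number 15.9 percentage points lower from compound 3 to compound 4 (beyond the scatter), and the 4-methoxybenzyl group in place of phenyl gives a number 15.9 percentage points lower from compound 2 to compound 4 (beyond the scatter). The gain seen with benzyl is not kept, with a number 3.8 percentage points lower from compound 1 to compound 4 (within the scatter). Nothing available accounts for this loss.

On these data alone, it remains open whether the drop belongs to methoxy itself or to any group at this place. A fluorine, a hydroxyl or a methyl on the same ring would separate the two readings.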